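Cyano in Place of Methyl on a Shared Core

A few compounds are considered here, and "the series" means these few. Any claim that something is new, unique, unknown or untested is made for them only; others in the source may bear on it.

Three measured compounds share one core and differ only in the groups carried on a six-membered aromatic ring of carbon only. In a functional assay on ACHN cells (Homo sapiens) for inhibition, read by sulforhodamine B assay (a higher number here means a weaker inhibitor of growth, a lower number a stronger inhibitor of growth), compound 1 `Cc1cccc(CN2CC=C(CCC(=O)NO)C2=O)c1` gives 3330 nM. Compound 3 `O=C(CCC1=CCN(Cc2cc(C(F)(F)F)cc(C(F)(F)F)c2)C1=O)NO` gives 3330 nM in this assay, level with compound 1 at the digits shown and within the scatter, so no order between the two can be stated; together they hold the highest numbers of the three. Compound 2 `CC(C)(C)c1ccc(CN2CC=C(CCC(=O)NO)C2=O)cc1` gives 860 nM in this assay, a lower number than compound 1 by more than the scatter allows, so compound 2 is the stronger growth inhibitor of that pair.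

Compound 4 `N#Cc1cccc(CN2CC=C(CCC(=O)NO)C2=O)c1` has not yet been measured. It differs from compound 1 in one place: cyano in place of methyl on an aromatic carbon. Going by the values given here, no pair of measured compounds shows this change, so nothing measured tells its direction or size. The two measured variations on the ring give one case of no change (compound 3) and one clear drop (compound 2). Among the compounds with values here, with no closer precedent, compound 4 is expected to sit near compound 1. The step of a 1.1-fold higher number from compound 1 to compound 4 (0.02 log units; within the scatter) is expected to lie within the scatter. Compound 4 is therefore estimated at 3500 nM, with a likely range from 1200 nM to 10000 nM.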

Compound 4, concentration for 50% growth inhibition: 7750 nM
For compound 4 the middle estimate is 2.2-fold (0.35 log units) below the measured one, and the stated range covers the measured number.
By their numbers in this assay, from the lowest: compound 2; then compounds 1 and 3 (each within the scatter of the next); then compound 4.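

Cyano in place of methyl on this aromatic carbon, meta to a large group, gives a 2.3-fold higher number from compound 1 to compound 4 (0.37 log units; beyond the scatter) in this assay, so compound 4 is a weaker inhibitor of growth than compound 1. The step is modest, but it is the first change at a single place that can be read directly among these compounds, and it shows that this position is not indifferent to the group it carries. Nothing at hand speaks to what lies behind the step.

One pair cannot show whether methyl is a favourable group at this carbon or cyano an unfavourable one, and a plain hydrogen, a chlorine atom, a methoxy group or an amine on the same carbon would help to settle that. The same exchange at another carbon of the ring, or a carboxylic acid in place of the cyano group, would show whether the step depends on the position or on the particular group that enters there.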